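The compounds below may be only part of what the source reports. "The series", "measured", "known", "first", "only" and "open" are said of these compounds alone.

Working notes on the quinone oxime ether series.

Compound 1 `CO/N=C/c1cc(OC)c2c(c1OC)C(=O)C=CC2=O` is the smallest member. In a functional assay on A549 cells (Homo sapiens) for antiproliferative activity (on this read-out lower numbers stand for an effect already at smaller amounts and higher numbers for an effect only at larger amounts of compound), compound 1 gives > 10 ug/mL, which is a limit of the assay and not a number. Compound 2 `CCCCCCCCCO/N=C/c1cc(OC)c2c(c1OC)C(=O)C=CC2=O` carries octyl in place of hydrogen on a saturated chain carbon bound to an oxygen on an unsaturated carbon. In this assay compound 2 gives > 10 ug/mL, again a limit. The step that the two limits leave unreadable from compound 1 to compound 2 is therefore not readable. Compound 3 `CCCCCC/C(=N\OC)c1cc(OC)c2c(c1OC)C(=O)C=CC2=O` differs from compound 1 in more than one place; the difference between the two cores is not broken down here. In this assay compound 3 gives > 10 ug/mL, also a limit. All three values rest on (the limit of > 10 ug/mL in this assay, at which 3 of the 3 values shown sit).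

Compound 4 `CCCCCCCCCO/N=C(\CCCCCC)c1cc(OC)c2c(c1OC)C(=O)C=CC2=O` is not yet measured. It differs from compound 3 by octyl in place of hydrogen on a saturated chain carbon bound to an oxygen on an unsaturated carbon, the same change as from compound 1 to compound 2, at a place described in identical words. As that earlier step is unreadable, no size can be carried over. The step is expected to be a step that the limit leaves unreadable from compound 3 to compound 4, since compound 3 sits at the limit of > 10 ug/mL in this assay, at which 3 of the 3 values shown sit. For compound 4 in this assay the estimate is 14 ug/mL, within 6 ug/mL to 40 ug/mL, most likely reported only as a limit.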

Compound 4, concentration for half-maximal effect: > 10 ug/mL
Compound 4 gave a limit, no number (the forecaster's own chance of this, stated with the estimate: 80%); the middle value lies beyond the limit too.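

In this assay compound 4 gives > 10 ug/mL as a limit and not a number, so the step from compound 3 to compound 4 cannot be read, any more than the step from compound 1 to compound 2. The four compounds share one ceiling: the limit of > 10 ug/mL in this assay, at which 4 of the 4 values shown sit. They leave open whether octyl in place of hydrogen at this place has any effect on the read-out, and how large it would be.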